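This account rests on a few compounds, and the source may have more. Where it says the series, first, only, none or still open, it means among the compounds named here.

Measured compounds in this set:

compound 1, `C=C1C[C@]23C[C@@]1(O)CC[C@H]2c1ccc(O)c(C)c1[C@@H]3Cn1cc(-c2ccc(OC)cc2)nn1` — > 20000 nM
compound 2, `Cc1ccc(S(=O)(=O)Oc2ccc3c(c2C)[C@H](Cn2cc(-c4ccc(Br)cc4)nn2)[C@@]24CC(=O)[C@@](C)(CC[C@@H]32)C4)cc1` — > 20000 nM

Working notes on the series. In a functional assay on MCF7 cells (Homo sapiens) for cytotoxicity, read by MTT assay, with a stated time of 4 days (on this read-out higher numbers stand for weaker inhibition and lower numbers for stronger inhibition), compound 1 gives > 20000 nM, which is a limit of the assay and not a number. In this assay compound 2 likewise gives > 20000 nM, again a limit. Among the measured compounds shown here, compound 1 therefore stands at the assay limit, and so does the only other measured compound: the limit of > 20000 nM in this assay, at which 2 of the 2 values shown sit. For the measured compounds named here, no step between two measured compounds is available, since both values shown are limits and differ from each other in more than one place.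

The compound to be measured next is compound 3, `C=C1C[C@]23C[C@@]1(O)CC[C@H]2c1ccc(O)c(C)c1[C@@H]3Cn1cc(-c2ccccc2)nn1`. It differs from compound 1 by hydrogen in place of methoxy on an aromatic carbon.

Going by the values given here, with no measured step on which to judge the size of this change, and with compound 1 sitting at the limit, no step beyond the scatter is expected in this assay in either direction. Compound 3 is thus expected to sit at or near the limit as well, and the step that the limit leaves unreadable from compound 1 to compound 3 is estimated to be small. The estimate for compound 3 in this assay is 30000 nM, with a range from 8000 nM to 120000 nM, and a reported limit rather than a number is thought the most likely outcome.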

Compound 3, half-maximal inhibitory concentration: > 20000 nM
Compound 3: only a limit was reported; the forecaster's own chance of this, stated with the estimate: 80%; the middle value does not contradict the limit.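

No step can be read from compound 1 to compound 3 in this assay, since both results are limits of the assay and not numbers: the limit of > 20000 nM in this assay, at which 3 of the 3 values shown sit. The compounds shown leave open whether hydrogen in place of methoxy on an aromatic carbon changes the read-out at all, and how large any such change would be.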